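A Halogen Swap on the Anilino Ring

A few compounds are considered here, and "the series" means these few. Any claim that something is new, unique, unknown or untested is made for them only; others in the source may bear on it.

Measured so far:
compound 1 `Cc1n[nH]c2ccc(-c3nc4cnc(N5CCN(C)CC5)cn4c3Nc3ccccc3F)cc12` — "not determined" (no result reported) in a functional assay on MV4-11 cells (Homo sapiens) for inhibition, with a stated time of 120 h; a higher number here means a weaker inhibitor, a lower number a stronger inhibitor
compound 2 `Cc1n[nH]c2ccc(-c3nc4cnc(N5CCN(C)CC5)cn4c3Nc3ccc(Cl)cc3)cc12` — 3510 nM
compound 3 `Cc1n[nH]c2ccc(-c3nc4cnc(N5CCN(C)CC5)cn4c3Nc3ccc(Cl)cc3F)cc12` — 10400 nM

Compound 1 has no result in this assay. Among the two numbers available, compound 3 gives the highest, and its nearest neighbour is compound 2, which differs only by fluoro in place of hydrogen on an aromatic carbon; that step, a 3.0-fold higher number from compound 2 to compound 3 (0.47 log units; beyond the scatter), is the only one the set offers.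

Compound 4 `Cc1n[nH]c2ccc(-c3nc4cnc(N5CCN(C)CC5)cn4c3Nc3ccc(Cl)cc3Cl)cc12` is the next step from compound 3: chloro in place of fluoro on an aromatic carbon. Going by the values given here, no measured pair shows chloro in place of fluoro, so the one step known, from compound 2 to compound 3, bears on it only indirectly, showing that a change at this position can move the number by a modest amount. With nothing to indicate direction, compound 4 is expected to give a value near that of compound 3, a step of a 1.2-fold higher number from compound 3 to compound 4 (0.06 log units; within the scatter) not beyond the scatter. Compound 4 is therefore estimated at 12000 nM, in a range from 4000 nM to 36000 nM.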

Compound 4, half-maximal inhibitory concentration: 4720 nM
Compound 4: middle estimate off by 2.5-fold (0.41 log units), on the high side; low and high end bracket the measured number.
By their numbers in this assay, from the lowest: compounds 2 and 4 (each within the scatter of the next); then compound 3.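

Going by these compounds alone, this pair gives the first direct comparison of two halogens at this place, on an aromatic carbon ortho to a large group: in this assay, chloro in place of fluoro gives a change beyond the scatter (a 2.2-fold lower number from compound 3 to compound 4 (0.34 log units; beyond the scatter)). Measured against hydrogen at the same place, chloro stays within the scatter (a 1.3-fold higher number from compound 2 to compound 4 (0.13 log units; within the scatter)), whereas fluoro lies beyond it (a 3.0-fold higher number from compound 2 to compound 3 (0.47 log units; beyond the scatter)), so among these compounds only the fluoro compound stands apart. Nothing at hand explains why the two halogens differ.

Compound 1 has no number, so whether fluoro acts the same way without the second chloro group cannot be read. As far as these compounds go, it also remains open whether a methyl group, a methoxy group or an amine at this place would stay close to compound 2.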